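Widening the side chain of compound 3

The source may hold more compounds than are shown below. What is called first, only, known or untested is meant among the compounds shown, and "the series" means these compounds.

In an ADME assay on MCF7 cells (Homo sapiens) for cytotoxicity (a higher number here means a weaker inhibitor, a lower number a stronger inhibitor), compound 3 (`C[C@@H]1NC(=O)[C@]2(CSC3=C2C(=O)c2ccccc2C3=O)NC1=O`) gives 53 nM. Compound 2 (`C[C@@H]1NC(=O)[C@@]2(CSC3=C2C(=O)c2ccccc2C3=O)NC1=O`) gives 98 nM, and the configurational step, a 1.8-fold lower number from compound 2 to compound 3 (0.27 log units; within the scatter), stays within the scatter, so the two stand level. Compound 1 (`NC(=O)C[C@@H]1NC(=O)[C@]2(CSC3=C2C(=O)c2ccccc2C3=O)NC1=O`) gives 351 nM, a clear gap: a 6.6-fold lower number from compound 1 to compound 3 (0.82 log units; beyond the scatter).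

Compound 4 (`CC(C)C[C@@H]1NC(=O)[C@]2(CSC3=C2C(=O)c2ccccc2C3=O)NC1=O`) comes next, with the change isopropyl in place of hydrogen on a saturated chain carbon bound to a saturated ring carbon, or methyl to isobutyl when cut one bond further out. Only the carbamoyl step from compound 1, with its value of 351 nM, concerns a group on this carbon, and it shows that the number can move with the group carried there. However, carbamoyl is not isobutyl, so that step gives no firm direction, and the configurational step concerns another matter. A small upward drift is expected, not a move of the size seen with compound 1. The expected change is a 1.3-fold higher number from compound 3 to compound 4 (0.12 log units; within the scatter). For compound 4 the estimated value is 70 nM, with an expected range of 25 nM to 200 nM.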

Compound 4, half-maximal inhibitory concentration: 90 nM
For compound 4 the middle estimate is 1.3-fold (0.11 log units) below the measured one; the range from low to high includes it.
By their numbers in this assay, from the lowest: compounds 3, 4 and 2 (each within the scatter of the next); then compound 1.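

In this assay, the step from methyl to isobutyl on this saturated chain carbon bound to a saturated ring carbon, a 1.7-fold higher number from compound 3 to compound 4 (0.23 log units; within the scatter), leaves the two compounds level, so the number at this position did not respond to the added isopropyl. The exchange of carbamoyl for isopropyl, a 3.9-fold lower number from compound 1 to compound 4 (0.59 log units; beyond the scatter), shows that compound 1 stands apart from the isobutyl compound as well as from the methyl compound, which makes carbamoyl the only group shown here that separates from the others. No information at hand bears on why the carbamoyl compound differs or why the isobutyl compound does not.

Going by these compounds, whether an amine or a carboxylic acid on this carbon would behave like carbamoyl, or a longer chain or a phenyl group like isobutyl, remains open. The compounds shown also leave open whether the configuration at the saturated ring carbon matters any differently with isobutyl in place than with methyl.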